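Ethoxycarbonyl for Iodo: What the Dose May Become

This account rests on a few compounds, and the source may have more. Where it says the series, first, only, none or still open, it means among the compounds named here.

Among the measured compounds shown here, compound 2 `CC1CC/C(=N\Nc2cccc(I)c2)c2ncc(C(=O)O)c(=O)n21` is the one compound of the three measured that gives a number in a functional assay on the whole organism for inhibition, with Rattus norvegicus as the target (on this read-out higher numbers stand for an effect only at larger amounts of compound and lower numbers for an effect already at smaller amounts), namely 1000 umol/kg. Compound 1 `CC1CC/C(=N\Nc2ccccc2Cl)c2ncc(C(=O)O)c(=O)n21` reaches only a limit of this assay, > 1000 umol/kg. Compound 3 `CC1CC/C(=N\Nc2ccc(O)cc2)c2ncc(C(=O)O)c(=O)n21` also gives only a limit, > 100 umol/kg. The steps of a number no higher from compound 1 to compound 2 (the limit leaves the size open), a step that the two limits leave unreadable from compound 1 to compound 3 and a step that the limit leaves unreadable from compound 2 to compound 3 remain of unreadable size because one value sits at the limit of > 100 umol/kg in this assay, at which 1 of the 3 values shown sits, and another at the limit of > 1000 umol/kg in this assay, at which 1 of the 3 values shown sits.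

Compound 4 `CCOC(=O)c1cccc(N/N=C2\CCC(C)n3c2ncc(C(=O)O)c3=O)c1` differs from compound 2 by ethoxycarbonyl in place of iodo on an aromatic carbon. For the measured compounds named here, no measured step of readable size bears on this change, so no step beyond the scatter is expected, which is no change at the digits printed from compound 2 to compound 4 (within the scatter). Compound 4 is therefore estimated at 1000 umol/kg in this assay, with a range from 300 umol/kg to 3000 umol/kg.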

Compound 4, dose for 50% inhibition: > 100 umol/kg
Compound 4: no number, only a limit; the forecaster's own chance of this, stated with the estimate: 50%; the middle value is on the limit's open side.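

In this assay compound 4 gives > 100 umol/kg as a limit, so its step from compound 2 cannot be read: the limit of > 100 umol/kg in this assay, at which 2 of the 4 values shown sit.

On these data alone, whether ethoxycarbonyl in place of iodo calls for a larger or smaller dose stays open.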